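The compounds below may be only part of what the source reports. "The series", "measured", "known", "first", "only" and "open" are said of these compounds alone.

Working notes on the series. Compound 2 `CCN(CC)CN1C(=O)/C(=N/NC(=S)Nc2ccc(C)cc2)c2ccccc21` gives 100000 nM in an ADME assay on HEL cells (Homo sapiens) for cytotoxicity; on this read-out lower numbers stand for higher toxicity in this test and higher numbers for lower toxicity in this test. Compound 3 `CCN(CC)CN1C(=O)/C(=N/NC(=S)Nc2ccc(C)cc2)c2cc(Cl)ccc21` gives 100000 nM in this assay; the difference between the two cores, (hydrogen in place of chloro on an aromatic carbon), made no change at the digits printed from compound 2 to compound 3 (within the scatter). Compound 1 `CCN(CC)CN1C(=O)/C(=N/NC(N)=S)c2cc(Cl)ccc21` is reported only as a limit in this assay, > 100000 nM. The change hydrogen in place of 4-methylphenyl on an amide-type nitrogen thus made a number no lower from compound 3 to compound 1 (the limit leaves the size open), a reading that rests on (the limit of > 100000 nM in this assay, at which 1 of the 3 values shown sits). Compound 4 `CCN(CC)CN1C(=O)/C(=N/NC(N)=S)c2ccccc21` is not yet measured in this assay; it carries the same change on the core of compound 2, (hydrogen in place of 4-methylphenyl on an amide-type nitrogen), and the surroundings of the place read the same in both pairs. The step of no change at the digits printed from compound 2 to compound 4 (within the scatter) is expected, resting on the earlier step of a number no lower from compound 3 to compound 1 (the limit leaves the size open). Compound 4 is estimated at 100000 nM, between 50000 nM and 300000 nM, with a fair chance of again being returned as a limit.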

Compound 4, minimum cytotoxic concentration: > 100000 nM
Compound 4: a limit, no number; the forecaster's own chance of this, stated with the estimate: 60%; the middle value lies on the limit itself.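

In this assay, compound 4 is reported only as a limit, and putting hydrogen in place of 4-methylphenyl on the amide-type nitrogen gives a number no lower from compound 2 to compound 4 (the limit leaves the size open). Set beside the earlier step on the chlorinated core, the change reads in the same direction, but no size can be compared: the same change on two cores in this assay, a number no lower (the limit leaves the size open) from compound 3 to compound 1 and a number no lower (the limit leaves the size open) from compound 2 to compound 4; the limit leaves it open whether they differ. The series therefore shows no lower number on either core, but it does not show that the change carries over with equal size, and the step from compound 1 to compound 4 cannot be read either: the limit of > 100000 nM in this assay, at which 2 of the 4 values shown sit.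

What number lies behind the limits of compound 1 and compound 4 remains open. Also open, on these data alone, is how the series reads with a longer chain, such as butyl, or a phenyl carrying a carboxylic acid on that nitrogen.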